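Working notes: methoxycarbonyl in place of isopropyl

The source may report more compounds than this note shows. Statements on the series, on what has been measured and on what is new or still open speak of the compounds shown alone.

Compound 1 `COc1cc(/C=C/C(=O)c2cccc(NC(=O)c3ccc(Cl)cc3Cl)c2)ccc1O`: 0.4 ug/mL
Compound 2 `COc1cc(/C=C/C(=O)c2cccc(NC(=O)C(C)C)c2)ccc1O`: 1.44 ug/mL

In a functional assay on HUVEC cells (Homo sapiens) for inhibition (a lower number here means a stronger inhibitor, a higher number a weaker inhibitor), compound 2 has the higher number of the two measured compounds, at 1.44 ug/mL. Compound 3 `COC(=O)C(=O)Nc1cccc(C(=O)/C=C/c2ccc(O)c(OC)c2)c1` carries methoxycarbonyl in place of isopropyl on a carbonyl carbon. For the measured compounds named here, the only measured step at this place is a 3.6-fold higher number from compound 1 to compound 2 (0.56 log units; beyond the scatter), and it replaces a 2,4-dichlorophenyl group. Neither group in the present change has a ring, so a smaller step is expected, probably none beyond the scatter, and the data do not settle its direction. The expected outcome is a 1.1-fold higher number from compound 2 to compound 3 (0.05 log units; within the scatter). For compound 3 the estimate is 1.6 ug/mL, with an expected range of 0.6 ug/mL to 4 ug/mL.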

Compound 3, half-maximal inhibitory concentration: 1.5 ug/mL
Estimate against measurement, compound 3: 1.1-fold (0.03 log units) above; the measured number falls inside the stated range.
By their numbers in this assay, from the lowest: compound 1; then compounds 2 and 3 (each within the scatter of the next).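

At this carbonyl carbon, methoxycarbonyl and isopropyl are not separated in this assay: a 1.0-fold higher number from compound 2 to compound 3 (0.02 log units; within the scatter), even though methoxycarbonyl has 2 hydrogen-bond acceptors and isopropyl has none. The 2,4-dichlorophenyl group is the only one of the three with a ring, and it stands apart from both ring-free groups, with a 3.8-fold higher number from compound 1 to compound 3 (0.57 log units; beyond the scatter) matching the earlier step to isopropyl in size. No supporting data bear on the reason for this pattern. From the compounds shown here alone, whether an unsubstituted phenyl, a longer alkyl chain or a carboxylic acid at this place would track with 2,4-dichlorophenyl or with the ring-free groups remains open.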